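Urea Analogues Tested on Gastric Cancer Cells

The compounds below may be only part of what the source reports. "The series", "measured", "known", "first", "only" and "open" are said of these compounds alone.

Three compounds share one core and differ only in the group on an amide-type nitrogen. Compound 1 `Cc1ccc(NC(=O)Nc2cccc(CNc3nccnc3Cl)c2)cc1C` gives 9870 nM in a functional assay on MGC-803 cells (Homo sapiens) for antiproliferative activity, read by MTT assay, with a stated time of 48 h; on this read-out higher numbers stand for weaker inhibition and lower numbers for stronger inhibition. Compound 2 `O=C(Nc1cccc(CNc2nccnc2Cl)c1)Nc1ccc(Cl)cc1Br` gives 7480 nM, and compound 3 `O=C(Nc1ccc(Cl)cc1)Nc1cccc(CNc2nccnc2Cl)c1` gives 4980 nM, the lowest of the three numbers, although the steps of a 2.0-fold lower number from compound 1 to compound 3 (0.30 log units; within the scatter) and a 1.5-fold lower number from compound 2 to compound 3 (0.18 log units; within the scatter) both lie within the scatter. Compound 4 `Cc1ccccc1NC(=O)Nc1cccc(CNc2nccnc2Cl)c1` carries 2-methylphenyl in place of 4-chlorophenyl on an amide-type nitrogen. The steps of a 2.0-fold lower number from compound 1 to compound 3 (0.30 log units; within the scatter) and a 1.3-fold lower number from compound 1 to compound 2 (0.12 log units; within the scatter) show that methyl groups on this phenyl ring went with slightly higher numbers, and all three measured steps are small. The step of a 1.4-fold higher number from compound 3 to compound 4 (0.15 log units; within the scatter) is therefore expected to be a modest rise, within the scatter. Compound 4 is estimated at 7000 nM, with a range from 3500 nM to 14000 nM.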

Compound 4, half-maximal inhibitory concentration: 14000 nM
The estimate for compound 4 lay 2.0-fold (0.30 log units) below the measured number, within the range that was stated.
By their numbers in this assay, from the lowest: compounds 3, 2, 1 and 4 (each within the scatter of the next, the first and the last beyond it).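

Within the data shown here, at this amide-type nitrogen, 2-methylphenyl in place of 4-chlorophenyl gives the first step in this assay that clears the scatter (a 2.8-fold higher number from compound 3 to compound 4 (0.45 log units; beyond the scatter)). The other two steps stay within it (a 1.9-fold higher number from compound 2 to compound 4 (0.27 log units; within the scatter); a 1.4-fold higher number from compound 1 to compound 4 (0.15 log units; within the scatter)), so compound 4 stands apart from compound 3 alone. No evidence here accounts for this gap. Still open, from the compounds shown here alone, is how the number would respond if the phenyl ring on this nitrogen carried an amine or a carboxylic acid, or if a longer carbon chain took the place of that ring.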